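Replacing the amide nitrogen of a sulfonamide by oxygen

The source may report more compounds than this note shows. Statements on the series, on what has been measured and on what is new or still open speak of the compounds shown alone.

Of the compounds shown here, three sharing one core have been measured in an assay on HEK293 cells for inhibition of solute carrier family 22 member 12 (Homo sapiens); a higher number here means a weaker inhibitor, a lower number a stronger inhibitor. Compound 1 `O=C(O)CSc1nnc(Br)n1Cc1ccc(Br)c2ccccc12` gives 94 nM; compound 2 `Oc1c(Br)cc(CSc2nnc(Br)n2Cc2ccc(Br)c3ccccc23)cc1Br` gives 119000 nM; compound 3 `NS(=O)(=O)CSc1nnc(Br)n1Cc1ccc(Br)c2ccccc12` gives 365000 nM, the highest of the three, with compound 2 nearest at a 3.1-fold higher number from compound 2 to compound 3 (0.49 log units; beyond the scatter) and compound 1 furthest at a 3900-fold higher number from compound 1 to compound 3 (3.59 log units; beyond the scatter). Compound 4 `O=S(=O)(O)CSc1nnc(Br)n1Cc1ccc(Br)c2ccccc12` differs from compound 3 by hydroxy in place of amino on a sulfonyl sulfur. The step that bears on it most is a 3900-fold higher number from compound 1 to compound 3 (3.59 log units; beyond the scatter), where the carboxy of compound 1 gave way to sulfamoyl; compound 4 returns a hydroxy to that end of the chain, so a large drop back toward compound 1 is expected, though not all the way. Compound 4 is therefore estimated at 2000 nM, in the range 150 nM to 30000 nM, a step of a 180-fold lower number from compound 3 to compound 4 (2.26 log units; beyond the scatter).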

Compound 4, half-maximal inhibitory concentration: 14400 nM
The estimate for compound 4 lay 7.2-fold (0.86 log units) below the measured number; the measured number falls inside the stated range.
By their numbers in this assay, from the lowest: compound 1; then compound 4; then compound 2; then compound 3.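

In this assay a single atom on the sulfonyl sulfur counts: hydroxy in place of amino gives a 25-fold lower number from compound 3 to compound 4 (1.40 log units; beyond the scatter) for this position, and sulfo also improves on 3,5-dibromo-4-hydroxyphenyl, with an 8.3-fold lower number from compound 2 to compound 4 (0.92 log units; beyond the scatter) on the same chain carbon. Even so, sulfo does not match carboxy, with a 150-fold higher number from compound 1 to compound 4 (2.19 log units; beyond the scatter) showing that carboxy remains the best of these groups. Nothing measured here accounts for these differences. Still open, going by these compounds, is how a phosphonic acid on this carbon, or a longer chain carrying the carboxylic acid, would compare with carboxy.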